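The source may hold more compounds than are shown below. What is called first, only, known or untested is meant among the compounds shown, and "the series" means these compounds.

Measured so far in a functional assay on HT-29 cells (Homo sapiens) for inhibition, read by MTT assay, with a stated time of 48 h; a lower number here means a stronger inhibitor, a higher number a weaker inhibitor:
compound 1, `Cc1ccc(NC(=O)NC(=O)c2ccc(OCc3cccc(C(F)(F)F)c3)cc2)cc1-c1nc2ccccc2[nH]1`: 3520 nM
compound 2, `Cc1ccc(NC(=O)NC(=O)c2ccc(OCc3ccccc3F)cc2)cc1-c1nc2ccccc2[nH]1`: 760 nM
compound 3, `Cc1ccc(NC(=O)NC(=O)c2ccc(OCc3cccc(Cl)c3Cl)cc2)cc1-c1nc2ccccc2[nH]1`: 48500 nM

Compound 3 stands at the highest number of the three; it is the weakest inhibitor here, with compound 1 nearest and compound 2 furthest. Compound 4, `Cc1ccc(COc2ccc(C(=O)NC(=O)Nc3ccc(C)c(-c4nc5ccccc5[nH]4)c3)cc2)cc1`, differs from compound 3 in one place: 4-methylphenyl in place of 2,3-dichlorophenyl on a saturated chain carbon bound to an oxygen on an aromatic ring. Within the data shown here, no measured step swaps exactly these two groups. The two steps that reach compound 3 by a change at the same place, a 14-fold higher number from compound 1 to compound 3 (1.14 log units; beyond the scatter) and a 64-fold higher number from compound 2 to compound 3 (1.80 log units; beyond the scatter), both run to markedly higher numbers, so this position clearly moves the result. Replacing the 2,3-dichlorophenyl is therefore expected to bring the number back toward those of compounds 1 and 2, a step of a 16-fold lower number from compound 3 to compound 4 (1.21 log units; beyond the scatter). Compound 4 is estimated at 3000 nM, between 600 nM and 15000 nM.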

Compound 4, half-maximal inhibitory concentration: 5110 nM
Beside the measured number, compound 4's estimate is 1.7-fold (0.23 log units) below it; the measured number falls inside the stated range.
By their numbers in this assay, from the lowest: compound 2; then compounds 1 and 4 (each within the scatter of the next); then compound 3.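

In this assay, 4-methylphenyl gives back much of what 2,3-dichlorophenyl loses (a 9.5-fold lower number from compound 3 to compound 4 (0.98 log units; beyond the scatter)), but it stays short of 2-fluorophenyl (a 6.7-fold higher number from compound 2 to compound 4 (0.83 log units; beyond the scatter)). It cannot be told apart from 3-(trifluoromethyl)phenyl (a 1.5-fold higher number from compound 1 to compound 4 (0.16 log units; within the scatter)), so two different substituted phenyl groups can give matching results at this position, while compound 2 and compound 3 fall on either side of them. No measured evidence here explains these differences. Still open, as far as these compounds go, is whether a phenyl group carrying an amine or a carboxylic acid, or one joined through a longer chain, would stay in this range.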